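Swapping an amine for a methoxy group in a pyrimidine series

This account rests on a few compounds, and the source may have more. Where it says the series, first, only, none or still open, it means among the compounds named here.

Of the compounds shown here, two from this series have been measured in an in vivo ADME assay on the whole organism (strain Sprague-Dawley) for pharmacokinetics, with Rattus norvegicus as the target; a higher number here means faster removal of the compound, a lower number slower removal. Compound 1, `CCCCCOC(=O)N1CCN(C(=O)[C@H](CCC(=O)O)NC(=O)c2cc(N3CCC(C(=O)N4CCCC4)CC3)nc(-c3ccccc3)n2)CC1`, gives 2 mL/min/kg. Compound 2, `CCCCCOC(=O)N1CCN(C(=O)[C@H](CCC(=O)O)NC(=O)c2nc(-c3ccccc3)cc(N3CCC(CN)CC3)n2)CC1`, gives 16 mL/min/kg. Compound 2 therefore stands at the higher of the two numbers, and the gap between it and compound 1 lies beyond the usual scatter of repeated measurements, so compound 2 is cleared faster than compound 1.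

Compound 3, `CCCCCOC(=O)N1CCN(C(=O)[C@H](CCC(=O)O)NC(=O)c2nc(-c3ccccc3)cc(N3CCC(COC)CC3)n2)CC1`, differs from compound 2 in one spot: methoxy in place of amino on a saturated chain carbon bound to a saturated ring carbon. In plain terms, a 4-(aminomethyl)piperidin-1-yl group becomes a 4-(methoxymethyl)piperidin-1-yl group, one hydrogen-bond donor is lost and the acceptor count is kept.

For the measured compounds named here, no measured pair in this set shows this exact swap, so there is no direct precedent for its size. The step from compound 2 to compound 3 in this assay is expected to be small, a 1.6-fold lower number from compound 2 to compound 3 (0.20 log units; within the scatter), with a modest slowing of removal as the more likely direction but no change beyond the scatter being fully plausible. Starting from compound 2, which gives 16 mL/min/kg, compound 3 is estimated at 10 mL/min/kg, within a range of 4 mL/min/kg to 25 mL/min/kg.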

Compound 3, clearance: 6 mL/min/kg
Beside the measured number, compound 3's estimate is 1.7-fold (0.22 log units) above it; low and high end bracket the measured number.
By their numbers in this assay, from the lowest: compound 1; then compound 3; then compound 2.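

In this assay, for the compounds shown here, putting methoxy in place of amino on a saturated chain carbon bound to a saturated ring carbon gives a 2.7-fold lower number from compound 2 to compound 3 (0.43 log units; beyond the scatter), and this is the only step here between compounds that differ in one place. It shows that this position is not silent: with the rest of the molecule unchanged, going from aminomethyl to methoxymethyl slows removal from the rat by more than repeat measurements would be expected to scatter. Nothing available ties this change to any property of either group, or to the loss of the hydrogen-bond donor counted for amino, so the reason for it remains unknown.

The compounds shown leave open how other groups at this spot compare, for example a hydroxyl, a dimethylamino group or a longer chain such as ethoxymethyl, and so whether amino stands apart or methoxy does. They also leave open whether the same swap would slow removal to a similar degree on the core of compound 1, which differs from compound 2 in more than one place.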